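This account rests on a few compounds, and the source may have more. Where it says the series, first, only, none or still open, it means among the compounds named here.

The study compares four compounds on a shared core that carries an aryl group. Compound 1 `COc1ccc(-c2cc3cc(C4C(C#N)=C(N)OC5=C4C(=O)CCC5)cc(C(C)C)c3oc2=O)cc1` and compound 2 `COc1ccc(-c2cc3cc(C4C(C#N)=C(N)OC5=C4C(=O)CCC5)cc(C(C)C)c3oc2=O)cc1OC` share one core; compound 3 `COc1ccc(-c2cc3cc(C4C(C#N)=C(N)OC5=C4C(=O)CC(C)(C)C5)cc(C(C)C)c3oc2=O)cc1OC` and compound 4 `COc1cc(-c2cc3cc(C4C(C#N)=C(N)OC5=C4C(=O)CC(C)(C)C5)cc(C(C)C)c3oc2=O)cc(OC)c1OC` share another, and the difference between the two cores is not broken down here. In a functional assay on the whole organism (strain Swiss albino) with Mus musculus as the target, in the forced swim test, with a stated time of 5 min, at a dose of 0.5 mg/kg by the intraperitoneal route (a higher number here means more inhibition at the dose given (going by the name of the read-out), a lower number less inhibition), compound 1 gives 69.7%, and compound 2 gives 57.2%. Compound 2 differs from compound 1 by methoxy in place of hydrogen on an aromatic carbon, and this change made a step of a number 12.5 percentage points lower from compound 1 to compound 2 (beyond the scatter). Compound 3 gives 86.6% in this assay, the highest of the three numbers. Compound 4 differs from compound 3 by methoxy in place of hydrogen on an aromatic carbon. The place is not identical to that of the earlier change, since here the entering group is also meta to a methoxy group, so the change is the same kind of change, not the same one. With compound 3 as the starting point, the step from compound 3 to compound 4 is expected to be a number 12.6 percentage points lower from compound 3 to compound 4 (beyond the scatter), because the same kind of change gave a number 12.5 percentage points lower from compound 1 to compound 2 (beyond the scatter). Compound 4 is therefore estimated at 74%, with a likely range from 55% to 90%.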

Compound 4, a percentage reported as inhibition, in the whole organism at one dose (the size of the read-out at that dose, not a potency): 29.2%
For compound 4 the middle estimate is 44.8 percentage points above the measured one, and the stated range ends above it.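

In this assay, adding a methoxy group to turn 3,4-dimethoxyphenyl into 3,4,5-trimethoxyphenyl gave a number 57.4 percentage points lower from compound 3 to compound 4 (beyond the scatter), a step in the same direction as the earlier one. The same kind of change therefore did not carry over from one core to the other as a fixed amount: the same change on two cores in this assay, a number 12.5 percentage points lower (beyond the scatter) from compound 1 to compound 2 and a number 57.4 percentage points lower (beyond the scatter) from compound 3 to compound 4, 44.9 percentage points apart, beyond the scatter of two such steps The two steps differ in both the core and the place of the entering group, which here is also meta to a methoxy group, so this single pair cannot separate the two, and as readings at one dose it says nothing about potency.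

The compounds shown leave open whether the 3,4,5-trimethoxyphenyl group would give a similarly large step on the core of compound 1. They also leave open how a hydroxy group or a chlorine atom in the same place would behave on either core.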